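The source may hold more compounds than are shown below. What is called first, only, known or untested is meant among the compounds shown, and "the series" means these compounds.

Measured so far in an in vitro functional assay on cells for agonist activity at Bombesin receptor subtype-3 (Mus musculus), read by luminescence and calcium flux; a higher number here means that more compound is needed for the effect, a lower number that less compound is needed:

- compound 1 `O=C(O)c1ccccc1-c1ccc(CCc2ncc(CC3CCCCCC3)[nH]2)cc1` gives 5.7 nM
- compound 2 `CC(C)(C)Cc1cnc(CCc2ccc(-c3ccccc3C(=O)O)cc2)[nH]1` gives 6.3 nM
- compound 3 `O=C(O)c1ccccc1-c1ccc(CCc2ncc(Cc3ccc(Cl)cc3)[nH]2)cc1` gives 102 nM

Compound 3 stands highest of the three numbers: an 18-fold higher number from compound 1 to compound 3 (1.25 log units; beyond the scatter), and a 16-fold higher number from compound 2 to compound 3 (1.21 log units; beyond the scatter). Compounds 1 and 2 sit together, since a 1.1-fold higher number from compound 1 to compound 2 (0.04 log units; within the scatter).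

Compound 4 `O=C(O)c1ccccc1-c1ccc(CCc2ncc(C3CCCCC3)[nH]2)cc1` is the next member. Its change from compound 3 is cyclohexyl in place of 4-chlorobenzyl on an aromatic carbon. The two measured steps that bear on it run the other way: both the cycloheptyl and the tert-butyl group, each on a saturated chain carbon bound to an aromatic carbon, gave numbers far lower than the 4-chlorophenyl of compound 3, and both steps were large. Compound 4 carries a non-aromatic ring of carbon only, set directly on the aromatic carbon rather than on a saturated chain carbon, so the match to compounds 1 and 2 is not exact. Still, a large drop is expected, an 8.5-fold lower number from compound 3 to compound 4 (0.93 log units; beyond the scatter), back toward the region of compounds 1 and 2. Compound 4 is estimated at 12 nM, in the range 3 nM to 50 nM.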

Compound 4, half-maximal effective concentration: 14.7 nM
Compound 4: middle estimate off by 1.2-fold (0.09 log units), on the low side; the measured number falls inside the stated range.
By their numbers in this assay, from the lowest: compounds 1 and 2 (each within the scatter of the next); then compound 4; then compound 3.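

In this assay, cyclohexyl set directly on the aromatic carbon of the five-membered aromatic ring gives a 6.9-fold lower number from compound 3 to compound 4 (0.84 log units; beyond the scatter), so a non-aromatic ring of carbon only also stays well below the 4-chlorobenzyl number without a saturated chain carbon, and no compound shown goes against this. Cyclohexyl does not quite match the two chain-linked groups, however: replacing neopentyl gives a 2.3-fold higher number from compound 2 to compound 4 (0.37 log units; beyond the scatter), and replacing cycloheptylmethyl gives a 2.6-fold higher number from compound 1 to compound 4 (0.41 log units; beyond the scatter). No available data explain these differences.

Open, on these data alone, is how cyclohexylmethyl would read, since it would separate ring size from the saturated chain carbon, and whether phenyl placed directly on this aromatic carbon would track compound 3 or compound 4. As far as these compounds go, the effect of an amine or a hydroxyl on the cyclohexyl ring also remains open.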